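Aryl sulfonate series: methoxy to fluoro on the phenol ring

A few compounds are considered here, and "the series" means these few. Any claim that something is new, unique, unknown or untested is made for them only; others in the source may bear on it.

Measured so far in a functional assay on HT-29 cells (Homo sapiens) for antiproliferative activity, read by sulforhodamine B assay, with a stated time of 48 h; on this read-out higher numbers stand for weaker inhibition and lower numbers for stronger inhibition:
- `COc1ccc(OS(=O)(=O)c2ccc(N3CCN(C)C3=O)cc2)cc1` compound 1 : > 100000 nM
- `CN1CCN(c2ccc(S(=O)(=O)Oc3ccc(F)cc3)cc2)C1=O` compound 2 : > 100000 nM
- `CCN1CCN(c2ccc(S(=O)(=O)Oc3cccc(OC)c3)cc2)C1=O` compound 3 : 22000 nM

The value of compound 1 is a limit of this assay, not a number. The value of compound 2 is likewise a limit. Going by the values given here, compound 3 gives the only number in the set; the difference between its core and that of compound 1 is not broken down here. The step from compound 1 to compound 2 is a step that the two limits leave unreadable from compound 1 to compound 2, the change being (fluoro in place of methoxy on an aromatic carbon). The same kind of change leads from compound 3 to compound 4, `CCN1CCN(c2ccc(S(=O)(=O)Oc3cccc(F)c3)cc2)C1=O`, namely (fluoro in place of methoxy on an aromatic carbon); the place differs, para to a large group in the first pair, meta to a large group in the second. Given (the limit of > 100000 nM in this assay, at which 2 of the 3 values shown sit), the measured step says nothing about direction. Among the compounds with values here, compound 4 is therefore estimated at 40000 nM, a step of a 1.8-fold higher number from compound 3 to compound 4 (0.26 log units; within the scatter), which is expected to keep it near the one measured number. This expectation rests only on compound 3 and its value 22000 nM.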

Compound 4, half-maximal inhibitory concentration: > 100000 nM
Compound 4 gave a limit, no number; the forecaster's own chance of this, stated with the estimate: 35%; middle value at least 2.5-fold (0.39 log units) away from the limit.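

In this assay, going by these compounds alone, going from 3-methoxyphenyl to 3-fluorophenyl on the core of compound 3 gives an at least 4.5-fold higher number from compound 3 to compound 4 (0.65 log units; beyond the scatter), and the only number in the set is lost. On these data alone, compound 4 gives > 100000 nM, a limit of the assay, so the full size of this step is unknown, and the same change on the core of compound 1 cannot be read, as both ends of that step are limits. The change is therefore read on one core only and nothing shows that it carries over to the other, because nearly the whole set sits at one limit: the limit of > 100000 nM in this assay, at which 3 of the 4 values shown sit.

As far as these compounds go, whether an amine, a carboxylic acid or a longer chain in place of methoxy would give a number in this assay stays open. From the compounds shown here alone, compound 1 and compound 3 differ in more than one place, and which of those differences goes with the number for compound 3 also stays open.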